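The source may hold more compounds than are shown below. What is called first, only, known or untested is meant among the compounds shown, and "the series" means these compounds.

Measured so far:
- compound 1 `COc1ccc(S(C)(=O)=O)c(NCC2=NCCN2)c1`: < 100000 nM
- compound 2 `Cc1ccc(S(C)(=O)=O)c(NCC2=NCCN2)c1`: < 2000 nM

In a functional assay for agonist activity at Alpha-1D adrenergic receptor (Homo sapiens) (a lower number here means that less compound is needed, a higher number that more compound is needed for the effect), compound 1 gives < 100000 nM, which is a limit of the assay and not a number. In this assay compound 2 gives < 2000 nM, likewise only a limit. The step that the two limits leave unreadable from compound 1 to compound 2 therefore cannot be sized. Compound 3 `CS(=O)(=O)c1ccc(Cl)cc1NCC1=NCCN1` differs from compound 2 by chloro in place of methyl on an aromatic carbon. Within the data shown here, no measured step involves a chloro group, so nothing among the measured pairs bears directly on this change. Compound 3 is therefore expected to sit near compound 2, with a step that the limit leaves unreadable from compound 2 to compound 3 that is uncertain in both directions. The estimate for compound 3 is 800 nM, between 100 nM and 6000 nM.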

Compound 3, half-maximal effective concentration: < 100000 nM
Compound 3 gave a limit, no number (the forecaster's own chance of this, stated with the estimate: 30%); the middle value is on the limit's open side.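

In this assay, among these compounds, compound 3 gives < 100000 nM, a limit and not a number, so no step linking compound 1, compound 2 and compound 3 can be read. The compounds shown leave open how methoxy, methyl and chloro on this aromatic carbon compare in this assay.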